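Cyclohexyl for cyclopropyl on a weak antiproliferative amide

The compounds below may be only part of what the source reports. "The series", "measured", "known", "first", "only" and "open" are said of these compounds alone.

- compound 1 `CN1CCC(NC(=O)c2ccc(Cn3nc(-c4cnn(C)c4)c4ccccc4c3=O)cc2)CC1` gives 54300 nM
- compound 2 `Cc1noc(C)c1-c1nn(Cc2ccc(C(=O)NC3CC3)cc2)c(=O)c2ccccc12` gives > 100000 nM ( a limit )
- compound 3 `CC(=O)Nc1ccc(Sc2nc(Nc3cc(C)[nH]n3)cc(N3CCN(C)CC3)n2)cc1` gives 15300 nM

These three values come from a functional assay on A549 cells (Homo sapiens) for antiproliferative activity, read by MTT assay, with a stated time of 72 h (a higher number here means a weaker inhibitor, a lower number a stronger inhibitor), and form the whole measured record. Compound 2 stands at the limit of > 100000 nM in this assay, at which 1 of the 3 values shown sits, and so has a limit rather than a number. Compound 4 `Cc1noc(C)c1-c1nn(Cc2ccc(C(=O)NC3CCCCC3)cc2)c(=O)c2ccccc12` differs from compound 2 by cyclohexyl in place of cyclopropyl on an amide-type nitrogen and carries cyclohexyl in place of cyclopropyl on an amide-type nitrogen. Going by the values given here, no measured pair shows what such a change does in this assay here, so only a modest step towards stronger inhibition is expected, and a second limit would be no surprise. The estimated at least 1.2-fold lower number from compound 2 to compound 4 (0.09 log units; that floor lies within the scatter) is accordingly small. For compound 4 the expected value is 80000 nM and the estimated range runs from 30000 nM to 150000 nM in this assay.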

Compound 4, half-maximal inhibitory concentration: > 100000 nM
Compound 4: no number, only a limit (the forecaster's own chance of this, stated with the estimate: 45%); middle value at least 1.2-fold (0.09 log units) from the limit.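

Compound 2 and compound 4 both give a limit rather than a number, so no step can be read between them: the limit of > 100000 nM in this assay, at which 2 of the 4 values shown sit.

The compounds shown leave open what cyclohexyl in place of cyclopropyl on an amide-type nitrogen does to antiproliferative activity.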